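The compounds below may be only part of what the source reports. "The series", "measured", "known", "first", "only" and "open" are said of these compounds alone.

In a functional assay, with a stated time of 30 min (on this read-out higher numbers stand for weaker inhibition and lower numbers for stronger inhibition), compound 1 `COc1ccc(C2CC(=NOC(=O)c3ccc(Br)cc3)CC(c3ccc(OC)cc3)N2C)cc1` gives 121000 nM. Compound 2 `COc1ccc(C2CC(=NOC(=O)c3ccccc3OC(C)=O)CC(c3ccc(OC)cc3)N2C)cc1` gives 350000 nM, and compound 3 `COc1ccc(C2CC(=NOC(=O)c3cccc(O)c3)CC(c3ccc(OC)cc3)N2C)cc1` gives 34000 nM. Compound 3 thus carries the lowest number of the three: the step of a 3.6-fold lower number from compound 1 to compound 3 (0.55 log units; beyond the scatter) and the step of a 10-fold lower number from compound 2 to compound 3 (1.01 log units; beyond the scatter) both lie beyond the scatter, so compound 3 is the strongest inhibitor of the set so far, while the remaining step, a 2.9-fold higher number from compound 1 to compound 2 (0.46 log units; beyond the scatter), is modest.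

Compound 4 `COc1ccc(C2CC(=NOC(=O)c3cc(O)c(O)c(O)c3)CC(c3ccc(OC)cc3)N2C)cc1` differs from compound 3 in one place: 3,4,5-trihydroxyphenyl in place of 3-hydroxyphenyl on a carbonyl carbon. Among the compounds with values here, no measured step places further hydroxyl groups on a phenyl that already carries one. The step of a 3.6-fold lower number from compound 1 to compound 3 (0.55 log units; beyond the scatter) is the only one in which a hydroxyl enters, and it lowered the number by a modest amount. The expectation for compound 4 in this assay is therefore a small step, a 1.4-fold lower number from compound 3 to compound 4 (0.13 log units; within the scatter), toward a lower number, possibly not beyond the scatter. Compound 4 is estimated at 25000 nM, with a range from 8000 nM to 80000 nM.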

Compound 4, half-maximal inhibitory concentration: 18000 nM
Estimate against measurement, compound 4: 1.4-fold (0.14 log units) above, and the stated range covers the measured number.
By their numbers in this assay, from the lowest: compounds 4 and 3 (each within the scatter of the next); then compound 1; then compound 2.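

In this assay, the 3,4,5-trihydroxyphenyl group on this carbonyl carbon gives the first view of further hydroxyl groups on a phenyl that already carries one, and the two compounds cannot be told apart (a 1.9-fold lower number from compound 3 to compound 4 (0.28 log units; within the scatter)). Against the other groups at this position, the 3,4,5-trihydroxyphenyl group keeps a clear separation, both from the 4-bromophenyl group (a 6.7-fold lower number from compound 1 to compound 4 (0.83 log units; beyond the scatter)) and, by a large margin, from the 2-acetoxyphenyl group (a 19-fold lower number from compound 2 to compound 4 (1.29 log units; beyond the scatter)). No available evidence bears on what lies behind these numbers.

As far as these compounds go, it remains open whether the hydroxyl groups themselves matter here, or whether an amine or a carboxylic acid on the phenyl in their place would give a similar number. Also open, from the compounds shown here alone, is how a longer chain between the carbonyl carbon and the phenyl would read out.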